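Swapping Methoxy for Bromo on a Single Aromatic Carbon

The compounds below may be only part of what the source reports. "The series", "measured", "known", "first", "only" and "open" are said of these compounds alone.

Compound 1 `CN(C)C(=O)c1cc2cnc(Nc3ccc(NC(=O)C4(C(=O)Nc5cccc(Cl)c5)CC4)cc3)nc2n1C1CCCC1` gives 8.3%
Compound 2 `CN(C)C(=O)c1cc2cnc(Nc3ccc(NC(=O)C4(C(=O)Nc5cccc(C(F)(F)F)c5)CC4)cc3)nc2n1C1CCCC1` gives 15.7%
Compound 3 `COc1cccc(NC(=O)C2(C(=O)Nc3ccc(Nc4ncc5cc(C(=O)N(C)C)n(C6CCCC6)c5n4)cc3)CC2)c1` gives 77.2%

These three values come from a functional assay on A549 cells (Homo sapiens) for inhibition, read by CCK-8 assay, with a stated time of 72 h, tested at 1 uM (a higher number here means more inhibition of growth at the concentration tested, a lower number less inhibition of growth), and compound 3 stands highest of the three, beyond the scatter of both others. Compound 4 `CN(C)C(=O)c1cc2cnc(Nc3ccc(NC(=O)C4(C(=O)Nc5cccc(Br)c5)CC4)cc3)nc2n1C1CCCC1` has not yet been measured. It differs from compound 3 by a single change bromo in place of methoxy on an aromatic carbon that turns the 3-methoxyphenyl into a 3-bromophenyl.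

All three measured steps concern this same place. Methoxy in place of chloro gave a number 68.9 percentage points higher from compound 1 to compound 3 (beyond the scatter) and methoxy in place of trifluoromethyl gave a number 61.5 percentage points higher from compound 2 to compound 3 (beyond the scatter) so both steps are large and point the same way. Trifluoromethyl in place of chloro gave a number 7.4 percentage points higher from compound 1 to compound 2 (within the scatter) and the two compounds without methoxy therefore cannot be told apart. Bromo itself has not been tested on this scaffold, so the expectation rests on these three compounds alone. Compound 4 is expected to fall close to compound 1 and compound 2 rather than close to compound 3. The expected step is a number 62.2 percentage points lower from compound 3 to compound 4 (beyond the scatter) and it would be large and downward. In this assay compound 4 is estimated to give 15% within an expected range of 3% to 38% on this reading.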

Compound 4, percent growth inhibition at one concentration: 20.2%
Compound 4: the middle estimate sits 5.2 percentage points below what was measured; measured number inside the range.
By their numbers in this assay, from the lowest: compounds 1, 2 and 4 (each within the scatter of the next, the first and the last beyond it); then compound 3.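

In this assay, bromo in place of methoxy gave a number 57 percentage points lower from compound 3 to compound 4 (beyond the scatter) and so the high reading of compound 3 now stands against three different groups at this place rather than two, with none of the three coming near it. Bromo in place of trifluoromethyl gave a number 4.5 percentage points higher from compound 2 to compound 4 (within the scatter) and bromo in place of chloro gave a number 11.9 percentage points higher from compound 1 to compound 4 (beyond the scatter) and so the compounds without methoxy do not form one flat level: compound 1 and compound 4 can be told apart, while compound 2 cannot be told from either, though that gap is small beside the drop from methoxy. Nothing available here bears on why methoxy stands apart from these three groups.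

From the compounds shown here alone, whether the high reading is peculiar to methoxy, or is shared by a longer ether such as ethoxy, by hydroxy or by an amine such as dimethylamino, stays open on these compounds. Going by these compounds, each value is also a reading at one concentration, and how the four compounds compare across a range of concentrations stays open too.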